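A few compounds are considered here, and "the series" means these few. Any claim that something is new, unique, unknown or untested is made for them only; others in the source may bear on it.

Of the compounds shown here, three have been measured in an assay on HEK293 cells for positive allosteric modulation of metabotropic glutamate receptor 2 (Rattus norvegicus), read by thallium flux, with a stated time of 2.5 min; a higher number here means a larger maximal response, a lower number a smaller maximal response. Compound 1 `COc1cc(C(=O)O)ccc1OCCCCOc1ccc(C(=O)CC(C)C)c(O)c1C` gives 85.7%. Compound 2 `Cc1c(OCCCCOc2ccc(C(=O)O)c(Cl)c2)ccc(C(=O)CC(C)C)c1O` gives 80.5%, and compound 3 `Cc1c(OCCCCOc2ccc(C(=O)O)c(Cl)c2)ccc(C(=O)CC2CCCC2)c1O` gives 80.8%. The number of compound 2 lies within the scatter of both others: compound 3 is the nearest, compound 1 the furthest, and neither gap is large enough to count as a real difference.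

The one single-change step among these, a number 0.3 percentage points higher from compound 2 to compound 3 (within the scatter), swaps the cyclopentyl for the isopropyl on a saturated chain carbon bound to a carbonyl carbon and leaves the maximal response essentially unchanged.

Compound 4 `Cc1c(OCCCCOc2ccc(C(=O)O)cc2F)ccc(C(=O)CC(C)C)c1O` has not yet been measured. It differs from compound 2 as follows: 4-carboxy-2-fluorophenyl in place of 4-carboxy-3-chlorophenyl on an oxygen on a saturated carbon

For the measured compounds named here, no measured step touches this part of the molecule, so the step from compound 2 to compound 3 bears on it only indirectly, by showing that one change elsewhere left the read-out flat. Compound 1 and compound 2 differ in the same ring, and their numbers also lie within the scatter of each other. The expectation for compound 4 in this assay is therefore no step beyond the scatter, a number 0.5 percentage points lower from compound 2 to compound 4 (within the scatter). Compound 4 is estimated at 80%, within a range from 68% to 92%.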

Compound 4, largest response reached (reported as percent of maximum), in percent of the reference or control that the assay uses: 85%
Estimate against measurement, compound 4: 5 percentage points below, and the stated range covers the measured number.
By their numbers in this assay, from the lowest: compounds 2, 3, 4 and 1 (each within the scatter of the next).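

In this assay, the ring bearing the carboxy group now has measured single-change steps of its own: 4-carboxy-2-fluorophenyl in place of 4-carboxy-3-chlorophenyl gives a number 4.5 percentage points higher from compound 2 to compound 4 (within the scatter), and fluoro in place of methoxy on an aromatic carbon gives a number 0.7 percentage points lower from compound 1 to compound 4 (within the scatter). Both steps stay within the scatter, so among these compounds the maximal response does not separate chloro, fluoro and methoxy on this ring, although the first step changes both the halogen and the number in the group's name, and the two changes cannot be told apart. Nothing available explains why the read-out stays flat across these changes.

Going by these compounds, it remains open whether any group on this ring can move the maximal response beyond the scatter, for example a trifluoromethyl or a nitrile in place of the halogen, or a ring carrying the carboxy group alone. Also open, on these data alone, is whether replacing the carboxylic acid itself with an amide or a tetrazole, or using a longer chain between the two ether oxygens, would leave the response just as flat.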